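Trimming the Amine on Compound 2: Compound 3 Awaits Measurement

A few compounds are considered here, and "the series" means these few. Any claim that something is new, unique, unknown or untested is made for them only; others in the source may bear on it.

Measured so far:
compound 1, `CN(C)CCn1cc(S(=O)(=O)c2ccccc2)c2cccnc21`: 94%
compound 2, `CN(C)CCn1cc(S(=O)(=O)c2cc(Cl)cc(Cl)c2)c2cccnc21`: 80%

In a functional assay on HeLa cells for agonist activity at 5-hydroxytryptamine receptor 6 (Homo sapiens), read by immunoassay (a lower number here means a smaller maximal response, a higher number a larger maximal response), compound 1 reaches 94%, and compound 2 reaches 80%. For the measured compounds named here, the single measured step, a number 14 percentage points lower from compound 1 to compound 2 (beyond the scatter), is the only comparison available, and it concerns the aryl group on the sulfonyl sulfur. On the two numbers shown, compound 2 stands lowest, with compound 1 as its nearest neighbour a step beyond the scatter above it.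

Compound 3, `NCCn1cc(S(=O)(=O)c2cc(Cl)cc(Cl)c2)c2cccnc21`, keeps the 3,5-dichlorophenyl of compound 2 and differs from it only at the basic side chain: amino in place of dimethylamino on a saturated chain carbon, two bonds along the chain from an aromatic nitrogen. Going by the values given here, no measured step touches this part of the molecule; the step from compound 1 to compound 2 alters a different position and therefore gives no guidance on what the side chain contributes. With nothing to point either way, the expectation for compound 3 is a step of no more than the usual scatter, a number 2 percentage points lower from compound 2 to compound 3 (within the scatter), though the range must stay wide. Compound 3 is thus estimated at 78%, with a range from 60% to 95%.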

Compound 3, largest response reached (Emax), in percent of the reference or control that the assay uses: 65%
Compound 3: middle estimate off by 13 percentage points, on the high side; the measured number falls inside the stated range.
By their numbers in this assay, from the lowest: compound 3; then compound 2; then compound 1.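

For the compounds shown here, the side chain, which no earlier step had touched, does matter in this assay: amino in place of dimethylamino on a saturated chain carbon, two bonds along the chain from an aromatic nitrogen, gives a number 15 percentage points lower from compound 2 to compound 3 (beyond the scatter). This shows that the response depends on more than the aryl group on the sulfonyl sulfur, since a change at this second position also produces a modest step, as did a number 14 percentage points lower from compound 1 to compound 2 (beyond the scatter). The change removes two carbons and adds a hydrogen-bond donor, but this single pair cannot separate those differences, and nothing available explains the lower response.

The compounds shown leave open whether the response would fall in stages along the series, with a single methyl on the amine as in a 2-(methylamino)ethyl chain, and how a cyclic amine such as pyrrolidine or a longer chain such as 3-(dimethylamino)propyl would compare. They also leave open whether the same change from dimethylamino to amino would give a similar step with the unsubstituted phenyl of compound 1, or whether its effect depends on the 3,5-dichlorophenyl group.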